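This account rests on a few compounds, and the source may have more. Where it says the series, first, only, none or still open, it means among the compounds named here.

Three compounds have been measured in a functional assay on COLO 205 cells (Homo sapiens) for cytotoxicity, read by MTT assay, with a stated time of 24 h; on this read-out higher numbers stand for weaker inhibition and lower numbers for stronger inhibition:

Compound 1 `COc1ccccc1-n1cc(COc2c(/C=C\C(=O)O)ccc(OC)c2CC=C(C)C)nn1` gives 12200 nM
Compound 2 `COc1ccc(/C=C\C(=O)O)c(OCc2cn(-c3ccc(NC(=O)c4ccccc4)cc3)nn2)c1CC=C(C)C` gives 20300 nM
Compound 3 `COc1ccc(/C=C\C(=O)O)c(OCc2cn(-c3ccccc3F)nn2)c1CC=C(C)C` gives 14500 nM

Compound 3 stands second highest of these three numbers; its nearest neighbour is compound 1 and compound 2 lies furthest from it, yet both gaps fall within the scatter, so none of the three can be told apart on this read-out. Compound 4 `COc1ccc(/C=C\C(=O)O)c(OCc2cn(-c3cccc(C#N)c3)nn2)c1CC=C(C)C` has not yet been measured. It differs from compound 3 in one place: 3-cyanophenyl in place of 2-fluorophenyl on an aromatic nitrogen. Going by the values given here, one measured step bears on this change, since it also swaps the group on the same aromatic nitrogen: a 1.2-fold higher number from compound 1 to compound 3 (0.08 log units; within the scatter). Compound 2 carries a much larger group on that same aromatic nitrogen, and its number likewise stays within the scatter of compound 3. Nothing among these three compounds suggests that exchanging the group on this aromatic nitrogen moves the number beyond the scatter, so in this assay no step beyond the scatter is expected for compound 4 in either direction. Compound 4 is therefore expected to give about 15000 nM in this assay, with a range from 7000 nM to 35000 nM. The expected step of a 1.0-fold higher number from compound 3 to compound 4 (0.01 log units; within the scatter) would thus remain within the scatter.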

Compound 4, half-maximal inhibitory concentration: 26800 nM
Estimate against measurement, compound 4: 1.8-fold (0.25 log units) below, and the stated range covers the measured number.
By their numbers in this assay, from the lowest: compounds 1, 3, 2 and 4 (each within the scatter of the next, the first and the last beyond it).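

In this assay, 3-cyanophenyl in place of 2-fluorophenyl on the aromatic nitrogen gives a 1.8-fold higher number from compound 3 to compound 4 (0.27 log units; within the scatter), so this exchange cannot be told apart from the ordinary spread of repeated measurements. Set against the 2-methoxyphenyl group, the same 3-cyanophenyl gives a 2.2-fold higher number from compound 1 to compound 4 (0.34 log units; beyond the scatter), which is the first step at this position to pass beyond the scatter; it is a modest step towards weaker inhibition, and it shows that the group on this nitrogen can shift the number a little, even though every value here stays in the same broad range. No measurement at hand explains this small shift.

The compounds shown leave open whether the shift belongs to the nitrile itself or to where it sits on the phenyl ring, since 2-cyanophenyl and 3-fluorophenyl do not appear among them. They also leave open whether an amine or a carboxylic acid on that phenyl ring, or a longer alkyl chain in place of the ring, would bring a larger step in either direction.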